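The source may hold more compounds than are shown below. What is called first, only, known or untested is meant among the compounds shown, and "the series" means these compounds.

Measured compounds:
Compound 1, `O=C(/C(=C\c1ccc(O)c([N+](=O)[O-])c1)SCc1ccc(Br)cc1)c1ccc(Br)cc1`, gives 10000 nM in a functional assay on DU-145 cells (Homo sapiens) for inhibition, read by trypan blue exclusion, with a stated time of 96 h; on this read-out higher numbers stand for weaker inhibition of growth and lower numbers for stronger inhibition of growth.
Compound 2, `COc1cc(C(=O)/C(=C\c2ccc(O)c([N+](=O)[O-])c2)SCc2ccc(Br)cc2)cc(OC)c1OC`, gives 1000 nM in this assay.
Compound 3, `O=C(/C(=C\c1ccc([N+](=O)[O-])c(O)c1)SCc1ccc(Br)cc1)c1ccc(Br)cc1`, gives 10000 nM in this assay.

Compound 1 and compound 3 differ in one place only: 3-hydroxy-4-nitrophenyl in place of 4-hydroxy-3-nitrophenyl on a double-bonded chain carbon bound to a double-bonded chain carbon. The step this made is no change at the digits printed from compound 1 to compound 3 (within the scatter). Compound 2 gives the lowest number of the three, and its gap to each of the other two is beyond the scatter. How the core of compound 2 differs from the core of compound 1 is not broken down here.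

Among the measured compounds shown here, compound 4, `COc1cc(C(=O)/C(=C\c2ccc([N+](=O)[O-])c(O)c2)SCc2ccc(Br)cc2)cc(OC)c1OC`, is built from compound 2 by the same change as the one from compound 1 to compound 3: 3-hydroxy-4-nitrophenyl in place of 4-hydroxy-3-nitrophenyl on a double-bonded chain carbon bound to a double-bonded chain carbon. The place of the change is the same in both pairs. For the measured compounds named here, the step from compound 2 to compound 4 is therefore expected to be no change at the digits printed from compound 2 to compound 4 (within the scatter), because the one known instance of this change gave no change at the digits printed from compound 1 to compound 3 (within the scatter). This rests on a single pair, so the expectation carries some uncertainty. In this assay compound 4 is expected to give about 1000 nM, within a range from 400 nM to 3000 nM.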

Compound 4, concentration for 50% growth inhibition: 1000 nM
Estimate against measurement, compound 4: no gap at the digits printed; the measured number falls inside the stated range.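

In this assay, moving from the 4-hydroxy-3-nitrophenyl group to the 3-hydroxy-4-nitrophenyl group on the core of compound 2 gave no change at the digits printed from compound 2 to compound 4 (within the scatter). Set beside the earlier pair, the change reads the same on both cores: the same change on two cores in this assay, no change at the digits printed (within the scatter) from compound 1 to compound 3 and no change at the digits printed (within the scatter) from compound 2 to compound 4, 1.0-fold (0.00 log units) apart, within the scatter of two such steps. This supports carrying the change between these two cores without expecting a shift in growth inhibition, but two pairs cannot show that it would stay silent on every other core in this series, and they do not explain why the two groups read alike.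

The compounds shown leave open what would happen if an amine or a carboxylic acid stood in place of the nitro group, or if a methoxy group stood in place of the hydroxy group. They also leave open whether the same match would hold in a different cell line or with a different read-out.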